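Chloro to Methoxy on the Aryl Ring of Compound 1

The source may report more compounds than this note shows. Statements on the series, on what has been measured and on what is new or still open speak of the compounds shown alone.

Compound 1 `Cc1ccccc1-c1nn(-c2ccc(Cl)cc2)cc1CNCCN1CCN(C)CC1` was examined in an ADME assay on Huh-7 cells (Homo sapiens) for cytotoxicity; on this read-out lower numbers stand for higher toxicity in this test and higher numbers for lower toxicity in this test. In this assay compound 1 gives 17000 nM, the highest of the two numbers reported. Compound 3 `CN1CCN(CCCNCc2cn(-c3ccc(C(F)(F)F)cc3)nc2-c2ccc(C(F)(F)F)cc2)CC1` in this assay gives 2000 nM, a lower number and the nearest to that of compound 1, with a gap beyond the usual scatter. For compound 2 `Cc1ccccc1CNc1nn(-c2ccc(F)cc2F)cc1CNCCN1CCN(C)CC1` the result in this assay is a limit of the assay, > 20000 nM, and not a number, as the limit of > 20000 nM in this assay, at which 1 of the 3 values shown sits, records. Compound 4 `COc1ccc(-n2cc(CNCCN3CCN(C)CC3)c(-c3ccccc3C)n2)cc1` has not yet been measured. It differs from compound 1 in one place: methoxy in place of chloro on an aromatic carbon. Within the data shown here, no measured step of this kind exists in the set, and with compound 1 already at 17000 nM the change is expected to move the number by little, if at all beyond the scatter. Compound 4 is therefore estimated at 20000 nM, with a range of 7000 nM to 60000 nM in this assay, an expected step of a 1.2-fold higher number from compound 1 to compound 4 (0.07 log units; within the scatter).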

Compound 4, half-maximal cytotoxic concentration: > 20000 nM
Compound 4 ended at the assay's limit; the forecaster's own chance of this, stated with the estimate: 50%; the middle value lies on the limit itself.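

Among these compounds, the change from 4-chlorophenyl to 4-methoxyphenyl is the first step at this position that can be read in this assay, and it comes out as an at least 1.1-fold higher number from compound 1 to compound 4 (0.07 log units; that floor lies within the scatter). Going by these compounds, compound 4 carries a limit of the assay and not a number, so this step is only a floor and its true size stays unknown, but it does show that the change brings no fall in the number beyond the scatter. With compound 4, a second compound now ends at this limit, which leaves less room to tell compounds apart at the top of the read-out: the limit of > 20000 nM in this assay, at which 2 of the 4 values shown sit.

On these data alone, whether an amine, a carboxylic acid or a nitrile in place of the methoxy at this position would lower the number remains open. Also open, as far as these compounds go, is whether methoxy in place of chloro would give the same result on a core other than that of compound 1.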